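The source may report more compounds than this note shows. Statements on the series, on what has been measured and on what is new or still open speak of the compounds shown alone.

Three compounds from the same series have been looked at in an ADME assay for permeability, using PAMPA, with a stated time of 30 min, at pH 7.4 (on this read-out higher numbers stand for higher permeability and lower numbers for lower permeability), and compound 4 is the next to be put through it. Compound 1, `COc1ccc(-c2c(-c3ccc(OC)cc3)n(Cc3ccccc3)c3ncn([C@@H]4CCCC[C@H]4O)c(=N)c23)cc1`, carries two methoxyphenyl groups on the shared core and a 2-hydroxycyclohexyl group on the aromatic nitrogen; in this assay compound 1 reaches > 1000 10^-6 cm/s, which is a limit of the assay rather than a number. Compound 2, `N=c1c2c(-c3ccccc3)c(-c3ccccc3)n(CC3CCCCC3)c2ncn1[C@H]1CC[C@H](O)CC1`, has two phenyl groups and a cyclohexylmethyl group; for compound 2 this assay gives "nd" (no result reported), so no result is reported. Compound 3, `Cc1c(C)n(Cc2ccccc2)c2ncn([C@H]3CC[C@H](O)CC3)c(=N)c12`, replaces the two aryl groups with two methyl groups and keeps a 4-hydroxycyclohexyl group on the aromatic nitrogen. In this assay compound 3 gives < 1 10^-6 cm/s, a limit of the assay and not a number, so compound 3 sits at the lower edge of what the assay can report.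

Compound 4, `Cc1c(C)n(Cc2ccccc2)c2ncn(CCCO)c(=N)c12`, differs from compound 3 in one place: 3-hydroxypropyl in place of 4-hydroxycyclohexyl on an aromatic nitrogen. Because compound 3 already sits at the limit (the limit of < 1 10^-6 cm/s in this assay, at which 1 of the 3 values shown sits), there is little room for a further fall to show, and no reason from the numbers shown to expect a rise. The step from compound 3 to compound 4 is therefore expected to be a step that the limit leaves unreadable from compound 3 to compound 4, that is, none beyond the scatter. Compound 4 is estimated to give 0.5 10^-6 cm/s, with a range from 0.1 10^-6 cm/s to 3 10^-6 cm/s.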

Compound 4, apparent permeability: 609 10^-6 cm/s
Estimate against measurement, compound 4: 1200-fold (3.09 log units) below; the measured number lies above the stated range.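

In this assay, putting 3-hydroxypropyl in place of 4-hydroxycyclohexyl on the aromatic nitrogen gives an at least 600-fold higher number from compound 3 to compound 4 (2.78 log units; beyond the scatter), so this one place can carry a very large change in the read-out while the rest of the molecule stays the same. Going by these compounds alone, no earlier pair differed in a single place, and this pair also narrows down what changed: the counts of hydrogen-bond donors and acceptors stay equal, while the ring, its two defined stereocentres and some heavy atoms leave. The printed step is a minimum rather than an exact size, since compound 3 stands at a limit of the assay: the limit of < 1 10^-6 cm/s in this assay, at which 1 of the 4 values shown sits.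

This single pair cannot separate the loss of the ring from the loss of the stereocentres, and it does not show whether the same change would have a similar effect on a core carrying the aryl groups of compound 1. It also leaves open how a shorter 2-hydroxyethyl chain, a longer 4-hydroxybutyl chain, or an amine such as 3-aminopropyl would read at this position.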